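Methoxy in Place of Hydrogen: From Compound 2 to Compound 3

The source may report more compounds than this note shows. Statements on the series, on what has been measured and on what is new or still open speak of the compounds shown alone.

Measured compounds:
compound 1, `Brc1cn2ccnc2c(-c2ccc3ncn(C4CCCCC4)c3c2)n1`: 6.2%
compound 2, `c1ccc(-c2cn3ccnc3c(-c3ccc4ncn(C5CCCCC5)c4c3)n2)cc1`: 29.3%

Of the compounds shown here, two have been measured in a functional assay on DU-145 cells (Homo sapiens) for inhibition, read by sulforhodamine B assay, with a stated time of 48 h, tested at 10 uM; on this read-out higher numbers stand for more inhibition at the one concentration tested (going by the name of the read-out) and lower numbers for less inhibition. Compound 1 gives 6.2% and compound 2 gives 29.3%. For the measured compounds named here, the one step between them, a number 23.1 percentage points higher from compound 1 to compound 2 (beyond the scatter), came with phenyl in place of bromo on an aromatic carbon. Going by the values given here, on these two numbers compound 2 stands highest, with compound 1 the only neighbour, beyond the scatter below it.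

Compound 3, `COc1ccc(-c2cn3ccnc3c(-c3ccc4ncn(C5CCCCC5)c4c3)n2)cc1`, has not been measured. It differs from compound 2 by methoxy in place of hydrogen on an aromatic carbon. The group enters on an aromatic carbon of a six-membered aromatic ring of carbon only, para to a large group; cut one bond further out, the change reads phenyl to 4-methoxyphenyl.

Among the compounds with values here, no measured step bears directly on this change: the only step in hand, a number 23.1 percentage points higher from compound 1 to compound 2 (beyond the scatter), concerns the bromo to phenyl exchange, not a substituent on the phenyl. Compound 3 is therefore expected to stay close to compound 2, with a number 2.7 percentage points higher from compound 2 to compound 3 (within the scatter) not beyond the scatter. The estimate for compound 3 in this assay is 32%, within 10% to 58%.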

Compound 3, a percentage reported as inhibition, at one concentration (the size of the read-out at that concentration, not a potency): 81.8%
Estimate against measurement, compound 3: 49.8 percentage points below, and the stated range ends below it.
By their numbers in this assay, from the lowest: compound 1; then compound 2; then compound 3.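

In this assay the phenyl ring proves to be far from a silent part of the series: a methoxy of only 2 heavy atoms, placed on an aromatic carbon para to a large group, gives a number 52.5 percentage points higher from compound 2 to compound 3 (beyond the scatter) and so a large step, where the earlier exchange of bromo for phenyl gave only a modest one, a number 23.1 percentage points higher from compound 1 to compound 2 (beyond the scatter) in size. Read against the bromo compound, 4-methoxyphenyl gives a number 75.6 percentage points higher from compound 1 to compound 3 (beyond the scatter) and puts compound 3 highest of the three, with its steps to both others beyond the scatter, so the substituent on the phenyl ring counts for more here than the phenyl ring alone. Nothing available explains why this one added group changes the read-out so strongly.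

The compounds shown leave open whether the oxygen itself matters, since a hydroxy, a methyl, an ethoxy or a fluoro in the same place would each separate the oxygen from the added carbon. They also leave open whether the methoxy would do the same elsewhere on that ring, and whether the cyclohexyl group could give way to a smaller ring or a short chain without losing the gain.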